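This account rests on a few compounds, and the source may have more. Where it says the series, first, only, none or still open, it means among the compounds named here.

Measured compounds:
compound 1, `COc1cc2ncnc(NNC(=S)NC(=O)c3ccc(Cl)cc3)c2cc1OC`: 4590 nM
compound 2, `O=C(NC(=S)NNc1ncnc2ccccc12)c1ccccc1`: 2330 nM

Compound 1, `COc1cc2ncnc(NNC(=S)NC(=O)c3ccc(Cl)cc3)c2cc1OC`, was tested in a functional assay on KB cells (Homo sapiens) for cytotoxicity, read by MTT assay, with a stated time of 72 h (on this read-out lower numbers stand for stronger inhibition and higher numbers for weaker inhibition), and gave 4590 nM. For the measured compounds named here, the only other measured compound, compound 2, `O=C(NC(=S)NNc1ncnc2ccccc12)c1ccccc1`, gave 2330 nM in this assay, and the two numbers lie within the usual scatter of each other, so no difference between them can be read from the data. Going by the values given here, compound 2 differs from compound 1 in more than one place, so the data contain no single step between them.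

The unmeasured compound 3, `COc1cc2ncnc(NNC(=S)NC(=O)c3ccc(C(F)(F)F)cc3)c2cc1OC`, is derived from compound 1 by one change: trifluoromethyl in place of chloro on an aromatic carbon. Among the compounds with values here, no measured pair shows this exchange on this core. The estimate is therefore that the step of a 1.1-fold higher number from compound 1 to compound 3 (0.04 log units; within the scatter) stays within the usual scatter, with no direction favored. Compound 3 is thus expected to give about 5000 nM in this assay, with a range from 1800 nM to 14000 nM.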

Compound 3, half-maximal inhibitory concentration: 8840 nM
Beside the measured number, compound 3's estimate is 1.8-fold (0.25 log units) below it; the measured number falls inside the stated range.
By their numbers in this assay, from the lowest: compounds 2, 1 and 3 (each within the scatter of the next, the first and the last beyond it).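

In this assay, for the compounds shown here, the exchange of 4-chlorophenyl for 4-(trifluoromethyl)phenyl gives a 1.9-fold higher number from compound 1 to compound 3 (0.28 log units; within the scatter) and is the first step that differs in one place only. It shows that, on this aromatic carbon para to a large group, a substituent of four heavy atoms can replace one of a single heavy atom with no difference readable beyond the usual scatter, something compounds 1 and 2 could not show because they differ in more than one place. Nothing in the available data bears on why this step has the size it has.

On these data alone, it remains open whether an amine or a carboxylic acid at this position would also stay within the scatter of compound 1. As far as these compounds go, the same exchange on the core of compound 2 also remains open.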